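Trimethoxyphenyl Pyrazolines: Adding a Methoxy Group

The compounds below may be only part of what the source reports. "The series", "measured", "known", "first", "only" and "open" are said of these compounds alone.

Measured so far:
- compound 1, `FC(F)(F)c1ccc(C2CC(c3ccccc3)=NN2c2ccc(-c3ccccc3)nn2)cc1`: 50000 nM
- compound 2, `COc1cc(C2CC(c3ccccc3)=NN2c2ccc(-c3ccccc3)nn2)cc(OC)c1OC`: > 100000 nM

Of the compounds shown here, two sharing one core have been tested in a functional assay on Caco-2 cells (Homo sapiens) for antiproliferative activity, read by MTT assay, with a stated time of 24 h; a higher number here means a weaker inhibitor, a lower number a stronger inhibitor. Compound 1 gives 50000 nM in this assay. For compound 2 this assay reports only a limit, > 100000 nM. That places compound 2 at the weak end of the numbers shown, as noted in the observation that (the limit of > 100000 nM in this assay, at which 1 of the 2 values shown sits).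

Compound 3, `COc1ccc(C2=NN(c3ccc(-c4ccccc4)nn3)C(c3cc(OC)c(OC)c(OC)c3)C2)cc1`, differs from compound 2 in one place: methoxy in place of hydrogen on an aromatic carbon. Among the measured compounds shown here, no measured pair isolates this change, so there is no directly comparable step. Given that compound 2 sits at a limit in this assay, the expected step that the limit leaves unreadable from compound 2 to compound 3 is none beyond the usual scatter, with a fair chance that compound 3 also returns only a limit. Compound 3 is therefore estimated at 150000 nM in this assay, within a range from 60000 nM to 400000 nM.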

Compound 3, half-maximal inhibitory concentration: > 100000 nM
Compound 3 ended at the assay's limit (the forecaster's own chance of this, stated with the estimate: 70%); the middle value does not contradict the limit.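

No step can be read between compound 2 and compound 3 in this assay, since each returns only a limit: the limit of > 100000 nM in this assay, at which 2 of the 3 values shown sit.

The compounds shown leave open whether methoxy in place of hydrogen on an aromatic carbon changes the result in this assay.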